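This account rests on a few compounds, and the source may have more. Where it says the series, first, only, none or still open, it means among the compounds named here.

Within the data shown here, in a functional assay on MDA-MB-231 cells (Homo sapiens) for inhibition, read by MTT assay, with stated times of 18 h and 4 h (a lower number here means a stronger inhibitor, a higher number a weaker inhibitor), compound 1 (`CCCCCCCCCCOP(=O)(O)OCCSC(=S)N1CCCCCC1`) gives 11400 nM and holds the lower of the two numbers measured so far. Compound 2 (`CCCCCCCCCCOP(=O)(O)OCCSC(=S)N1CCCC1`) stands at 67000 nM and carries pyrrolidin-1-yl in place of azepan-1-yl on a thiocarbonyl carbon. That ring change amounts to a 5.9-fold higher number from compound 1 to compound 2 (0.77 log units; beyond the scatter) and is a modest step. Compound 3 (`CCCCCCCCOP(=O)(O)OCCSC(=S)N1CCCCCC1`) keeps the azepan-1-yl ring and has one change from compound 1: hydrogen in place of ethyl on a saturated chain carbon, eight bonds along the chain from an oxygen on an unsaturated carbon. Among the measured compounds shown here, no measured step touches the chain, so the ring step serves only as a rough gauge of size. A step in this assay no larger than that one is expected, most likely toward a higher number, although no measured chain change supports this direction. For compound 3 the estimated value is 25000 nM with an expected range from 9000 nM to 70000 nM on this evidence. This estimate means an expected 2.2-fold higher number from compound 1 to compound 3 (0.34 log units; beyond the scatter) in all.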

Compound 3, half-maximal inhibitory concentration: 27000 nM
The estimate for compound 3 lay 1.1-fold (0.03 log units) below the measured number; the measured number falls inside the stated range.
By their numbers in this assay, from the lowest: compound 1; then compound 3; then compound 2.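

In this assay, hydrogen in place of ethyl on a saturated chain carbon, eight bonds along the chain from an oxygen on an unsaturated carbon, gives a 2.4-fold higher number from compound 1 to compound 3 (0.37 log units; beyond the scatter) and so shows that the chain end, and not only the ring on the thiocarbonyl carbon, bears on the read-out. With the azepan-1-yl ring held fixed, the loss of ethyl moves toward a weaker inhibitor, the same direction as the ring change in compound 2, and compound 1 remains the strongest inhibitor of the three, with both of its steps beyond the scatter. Nothing available explains the effect of this chain change.

The compounds shown leave open whether a longer chain, such as dodecyl, would continue the direction seen between compound 3 and compound 1, as this single chain change stands on the azepan-1-yl ring alone. They also leave open how a piperidin-1-yl or morpholin-4-yl ring would compare on the thiocarbonyl carbon, and whether the chain change would have the same size on the pyrrolidin-1-yl ring.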